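From pyridin-4-yl to piperidin-4-yl on the shared core

This account rests on a few compounds, and the source may have more. Where it says the series, first, only, none or still open, it means among the compounds named here.

Values measured in a functional assay on LNCaP cells (Homo sapiens) for antiproliferative activity, read by MTT assay, with a stated time of 24 h (on this read-out higher numbers stand for weaker inhibition and lower numbers for stronger inhibition), are these:
Compound 1 `c1ccc(-c2noc(-c3ccncc3)n2)cc1` gives 710000 nM
Compound 2 `COc1ccc(-c2noc(-c3ccncc3)n2)cc1OC1CCCC1` gives > 1000000 nM
Compound 3 `COc1ccc(-c2noc(C3CCCN3)n2)cc1OC1CCCC1` gives 43 nM

Compound 2 stands at > 1000000 nM, which is a limit of the assay and not a number. Compound 4 `COc1ccc(-c2noc(C3CCNCC3)n2)cc1OC1CCCC1` has not yet been measured. It keeps the rest of compound 2 but carries piperidin-4-yl in place of pyridin-4-yl on an aromatic carbon. Among the compounds with values here, the one measured step that bears on this change is an at least 23000-fold lower number from compound 2 to compound 3 (4.36 log units; beyond the scatter), where pyrrolidin-2-yl took the place of pyridin-4-yl on that same carbon. That step was large, and there, as in compound 4, a non-aromatic ring replaces the aromatic one. Within the data shown here, a large move towards stronger inhibition in this assay is therefore expected, though with only a single step to go on, the range has to stay wide. The expected change is an at least 6600-fold lower number from compound 2 to compound 4 (3.82 log units; beyond the scatter). Compound 4 is estimated at 150 nM, with an expected range from 15 nM to 5000 nM.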

Compound 4, half-maximal inhibitory concentration: 10 nM
Estimate against measurement, compound 4: 15-fold (1.18 log units) above, and the stated range ends above it.
By their numbers in this assay, from the lowest: compound 4; then compound 3; then compound 1. At a limit, above all of these: compound 2.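

In this assay, piperidin-4-yl in place of pyridin-4-yl gives an at least 100000-fold lower number from compound 2 to compound 4 (5.00 log units; beyond the scatter), so the large gain at this aromatic carbon is not tied to pyrrolidin-2-yl alone: two different non-aromatic rings now show it. The choice between these two rings also matters, though far less, with a 4.3-fold lower number from compound 3 to compound 4 (0.63 log units; beyond the scatter). Compound 2 stands at a limit of the assay and not at a number, so the full size of its step to compound 4 stays unknown: the limit of > 1000000 nM in this assay, at which 1 of the 4 values shown sits.

It remains open whether the ring nitrogen matters, since the compounds shown include neither a cyclohexyl ring on this carbon nor a piperidine with a methyl group on its nitrogen. Also open, on these data alone, is how piperidin-4-yl would behave on the core of compound 1, which lacks the methoxy and cyclopentyloxy groups.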